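The compounds below may be only part of what the source reports. "The series", "measured", "known", "first", "only" and "open" are said of these compounds alone.

For the measured compounds named here, compound 1 `O/N=C(/Nc1cccc(Cl)c1)c1ccc2occc2c1` is the single compound here with a number rather than a limit. In an assay on tissue (HeLa cells) for inhibition of Indoleamine 2,3-dioxygenase 1 (Homo sapiens), read by spectrophotometry (a higher number here means a weaker inhibitor, a lower number a stronger inhibitor), compound 1 gives 1500 nM. Compound 2 `CC1CCN(C(=O)c2cccc(N/C(=N/O)c3ccc4occc4c3)c2)CC1` carries (4-methylpiperidin-1-yl)carbonyl in place of chloro on an aromatic carbon, and in this assay compound 2 gives only a limit of > 30000 nM. That change amounts to an at least 20-fold higher number from compound 1 to compound 2 (1.30 log units; beyond the scatter), which bears on the observation that (the limit of > 30000 nM in this assay, at which 1 of the 2 values shown sits).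

Compound 3 `O/N=C(/Nc1cccc(Cl)c1)c1ccc2oc(COCC3CC3)cc2c1` differs from compound 1 in another way: (cyclopropylmethoxy)methyl in place of hydrogen on an aromatic carbon. Going by the values given here, no measured step touches that ring carbon, so the one step recorded, from compound 1 to compound 2, concerns a different site and does not bear on this change. Without a guide, the expected step in this assay from compound 1 to compound 3 is a 1.3-fold lower number from compound 1 to compound 3 (0.10 log units; within the scatter), that is, none beyond the scatter. Compound 3 is therefore estimated at 1200 nM, within a range from 300 nM to 5000 nM.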

Compound 3, half-maximal inhibitory concentration: 17600 nM
Estimate against measurement, compound 3: 15-fold (1.17 log units) below; the whole stated range lies below it.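

In this assay, the aromatic carbon next to the ring oxygen proves sensitive to substitution: (cyclopropylmethoxy)methyl in place of hydrogen there gives a 12-fold higher number from compound 1 to compound 3 (1.07 log units; beyond the scatter). This is the only change shown at this carbon, and it shows that the number responds to a change on this part of the core as well as to one at the chloro site. For the compounds shown here, nothing measured here says why this change raises the number so far.

The compounds shown leave open whether a plain methyl, a hydroxymethyl or an aminomethyl group at this carbon would give a number close to that of compound 1 or one as high as that of compound 3. They also leave open whether the ether oxygen or the cyclopropyl ring of the new group goes with the higher number.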